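From methyl to methoxy on the double-bonded chain

A few compounds are considered here, and "the series" means these few. Any claim that something is new, unique, unknown or untested is made for them only; others in the source may bear on it.

Compound 1 `CCC=C(c1cc(OC)cc(OC)c1)c1ccc(OC)c(OC)c1`: > 10000 nM, a limit of the assay, not a number
Compound 2 `C=C(c1cc(OC)cc(OC)c1)c1ccc(OC)c(OC)c1`: > 10000 nM, a limit of the assay, not a number
Compound 3 `CC=C(c1cc(OC)cc(OC)c1)c1ccc(OC)c(OC)c1`: 480 nM

All three compounds were tested in a functional assay on HCT-116 cells (Homo sapiens) for cytotoxicity, read by scintillation counting and thymidine incorporation, with a stated time of 72 h; on this read-out higher numbers stand for weaker inhibition and lower numbers for stronger inhibition. Neither compound 1 nor compound 2 gives a true number: each meets (the limit of > 10000 nM in this assay, at which 2 of the 3 values shown sit). Only compound 3 has a measured value, 480 nM. The two steps to it are an at least 20-fold lower number from compound 1 to compound 3 (1.31 log units; beyond the scatter) and an at least 20-fold lower number from compound 2 to compound 3 (1.31 log units; beyond the scatter), which makes compound 3 the most potent of the three.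

Compound 4 `COC=C(c1cc(OC)cc(OC)c1)c1ccc(OC)c(OC)c1` has not been measured. It differs from compound 3 in one place: methoxy in place of methyl on a double-bonded chain carbon bound to a double-bonded chain carbon. Methoxy stands in place of methyl on a double-bonded chain carbon bound to a double-bonded chain carbon.

Both steps above changed the group on this same carbon, and both were large, so even a small swap here can matter. Ethyl is the closest measured match to methoxy, and it gave the first of those steps. Methoxy is not ethyl, however, so a smaller loss than that one seems likely.

In this assay the expected change is a 4.2-fold higher number from compound 3 to compound 4 (0.62 log units; beyond the scatter), toward weaker inhibition. For compound 4 the estimate is 2000 nM, with an expected range from 400 nM to 10000 nM.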

Compound 4, half-maximal inhibitory concentration: > 10000 nM
Compound 4 ended at the assay's limit (the forecaster's own chance of this, stated with the estimate: 35%); middle value at least 5.0-fold (0.69 log units) from the limit.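

In this assay, putting methoxy in place of methyl on this double-bonded chain carbon gives an at least 20-fold higher number from compound 3 to compound 4 (1.31 log units; beyond the scatter), a large loss of inhibition from a swap that adds one oxygen atom and one hydrogen-bond acceptor. Of the four groups shown on this carbon, only methyl gives a true number, while hydrogen, ethyl and methoxy all end at the same assay limit: the limit of > 10000 nM in this assay, at which 3 of the 4 values shown sit. The steps among compound 1, compound 2 and compound 4 cannot be read, and no order can be given among these three.

The compounds shown leave open whether the loss with methoxy comes from the oxygen atom itself or from the extra heavy atom, and whether a different group on this carbon, such as chloro or nitrile, would come closer to compound 3 with its 480 nM. On these data alone, how weak compound 4 truly is also stays open: its result is a limit and not a number.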